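Dimethylamino in Place of Methyl: From Compound 3 to Compound 4

The compounds below may be only part of what the source reports. "The series", "measured", "known", "first", "only" and "open" are said of these compounds alone.

Of the compounds shown here, three sharing one core have been measured in an assay on isolated protein for inhibition of protein phosphatase 1D (Homo sapiens), read by malachite green; a higher number here means a weaker inhibitor, a lower number a stronger inhibitor. Compound 1 `O=c1[nH]c2ccc(-c3csc(-c4ccc(F)c(F)c4)n3)cc2o1` gives < 20000 nM in this assay, which is a limit of the assay and not a number. Compound 2 `O=c1[nH]c2ccc(-c3csc(-c4ccc(F)c(C(F)(F)F)c4)n3)cc2o1` gives < 20000 nM in this assay, likewise a limit. The step that the two limits leave unreadable from compound 1 to compound 2 therefore cannot be read. Compound 3 `CCc1cc(F)ccc1-c1nc(-c2ccc3[nH]c(=O)oc3c2)cs1` gives < 20000 nM in this assay, again a limit. Compound 3 thus stands at the limit of < 20000 nM in this assay, at which 3 of the 3 values shown sit. None of the three values separates one compound from another.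

Compound 4 `CN(C)Cc1cc(F)ccc1-c1nc(-c2ccc3[nH]c(=O)oc3c2)cs1` is not yet measured. It differs from compound 3 by dimethylamino in place of methyl on a saturated chain carbon bound to an aromatic carbon. Among the compounds with values here, no measured step bears on this change: the only step between measured compounds, from compound 1 to compound 2, is unreadable because both of its values sit at the limit of < 20000 nM in this assay, at which 3 of the 3 values shown sit. With nothing readable to lean on, no direction can be expected for the change, and the estimate for compound 4 must be wide, with a real chance that the assay again reports only a limit. The step that the limit leaves unreadable from compound 3 to compound 4 is expected to be small or absent. Compound 4 is estimated at 15000 nM, between 2000 nM and 60000 nM.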

Compound 4, half-maximal inhibitory concentration: < 20000 nM
Compound 4 ended at the assay's limit (the forecaster's own chance of this, stated with the estimate: 70%); the middle value is on the limit's open side.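

In this assay, within the data shown here, compound 4 gives < 20000 nM, a limit of the assay and not a number, so no step from compound 3 to compound 4 can be read. The four compounds stand together: the limit of < 20000 nM in this assay, at which 4 of the 4 values shown sit. The compounds shown leave open how far apart their true values lie, and whether either change shifts them at all.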